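Bromo for nitro on the highest-scoring analogue

This account rests on a few compounds, and the source may have more. Where it says the series, first, only, none or still open, it means among the compounds named here.

Three analogues sharing one core have been run so far. Compound 1 `O=c1cc(-c2ccccc2)oc2cc(N3COc4ccccc4C3)ccc12` gives 3.89% in a functional assay on MCF7 cells (Homo sapiens) for inhibition, read by MTT assay, with a stated time of 48 h, tested at 15 ug/mL; on this read-out lower numbers stand for less inhibition of growth and higher numbers for more inhibition of growth at the one concentration tested. Among the measured compounds shown here, compound 3 `O=c1cc(-c2ccccc2)oc2cc(N3COc4c(cccc4[N+](=O)[O-])C3)ccc12` gives 1.96%, and the only single-point step between measured compounds, a number 1.9 percentage points lower from compound 1 to compound 3 (within the scatter), shows that adding the nitro on that attachment pattern changes nothing beyond the scatter. Compound 2 `O=c1cc(-c2ccccc2)oc2ccc(N3COc4c(cccc4[N+](=O)[O-])C3)cc12`, which carries the same nitro but with the core joined differently, gives 55.9% and stands highest of the three, above compound 1 by a margin beyond the scatter and above compound 3 likewise.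

Compound 4 `O=c1cc(-c2ccccc2)oc2ccc(N3COc4c(Br)cccc4C3)cc12` is the next member, related to compound 2 by bromo in place of nitro on an aromatic carbon. For the measured compounds named here, no measured step bears directly on swapping nitro for bromo; the one step involving nitro, from compound 1 to compound 3, was within the scatter and on a different attachment pattern, so it gives little guidance. The expectation is therefore a moderate downward step, a number 15.9 percentage points lower from compound 2 to compound 4 (beyond the scatter), with wide uncertainty. Compound 4 is estimated at 40%, in the range 10% to 65%.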

Compound 4, percent growth inhibition at one concentration: 37.8%
For compound 4 the middle estimate is 2.2 percentage points above the measured one, within the range that was stated.
By their numbers in this assay, from the lowest: compounds 3 and 1 (each within the scatter of the next); then compound 4; then compound 2.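

Working from this assay, bromo in place of nitro on this aromatic carbon gives a number 18.1 percentage points lower from compound 2 to compound 4 (beyond the scatter), the first step read at this position on the higher-scoring attachment pattern. The group on this carbon therefore does matter on that pattern, yet the inhibition does not rest on nitro alone, as compound 4 with bromo still gives 37.8%. Nothing available here explains why the number falls with this change.

Still open, as far as these compounds go, is what hydrogen on this carbon gives on the attachment pattern of compound 4, so the separate contributions of nitro and bromo cannot yet be set against an unsubstituted reference. Also open, from the compounds shown here alone, is whether an amine, a carboxylic acid or a methoxy group on the same carbon would keep, raise or lower the number.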